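Swapping one halogen on a shared core

The source may hold more compounds than are shown below. What is called first, only, known or untested is meant among the compounds shown, and "the series" means these compounds.

Measured in a functional assay on FM3A cells (Mus musculus) for inhibition; a higher number here means a weaker inhibitor, a lower number a stronger inhibitor:
- compound 1 `O=C1O/C(=C\Cn2cc(I)c(=O)[nH]c2=O)C(OCc2ccccc2)=C1OCc1ccccc1`: 22600 nM
- compound 2 `O=C1O/C(=C\Cn2ccc(=O)[nH]c2=O)C(OCc2ccccc2)=C1OCc1ccccc1`: 17700 nM
- compound 3 `O=C1O/C(=C\Cn2cc(Cl)c(=O)[nH]c2=O)C(OCc2ccccc2)=C1OCc1ccccc1`: 16900 nM

These three compounds share one core and differ only in a single group on an aromatic carbon. Compound 3, which carries chloro, has the value 16900 nM and cannot be told apart from the other two, since every gap among them lies within the scatter.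

The next compound is compound 4 `O=C1O/C(=C\Cn2cc(F)c(=O)[nH]c2=O)C(OCc2ccccc2)=C1OCc1ccccc1`, with fluoro in place of chloro on an aromatic carbon. Among the measured compounds shown here, three measured steps bear on this change. The closest is the exchange of one halogen for another, a 1.3-fold lower number from compound 1 to compound 3 (0.13 log units; within the scatter), and the other two are a 1.3-fold lower number from compound 1 to compound 2 (0.11 log units; within the scatter) and a 1.0-fold lower number from compound 2 to compound 3 (0.02 log units; within the scatter). All three are small, so this position has so far shown no measurable effect on the read-out. For the measured compounds named here, no fluoro compound has yet been measured, however, which leaves real uncertainty, especially toward lower numbers.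

The expected change is a 1.1-fold lower number from compound 3 to compound 4 (0.05 log units; within the scatter), which means no step beyond the scatter. For compound 4 the estimated value is 15000 nM, with an expected range from 3000 nM to 26000 nM.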

Compound 4, half-maximal inhibitory concentration: 3400 nM
Compound 4: the middle estimate sits 4.4-fold (0.64 log units) above what was measured; measured number inside the range.
By their numbers in this assay, from the lowest: compound 4; then compounds 3, 2 and 1 (each within the scatter of the next).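

Placing fluoro at this position moves the read-out in this assay after all: there is a 5.0-fold lower number from compound 3 to compound 4 (0.70 log units; beyond the scatter) when fluoro replaces chloro, a 5.2-fold lower number from compound 2 to compound 4 (0.72 log units; beyond the scatter) when it replaces hydrogen, and a 6.6-fold lower number from compound 1 to compound 4 (0.82 log units; beyond the scatter) when it replaces iodo. Hydrogen, chloro and iodo remain within the scatter of one another, so among these four compounds only fluoro stands apart, and compound 4 is the strongest inhibitor of the set, with its steps to all three others beyond the scatter. Nothing available here gives a measured reason why fluoro separates from the other three groups.

The compounds shown carry only a single atom at this position, so it remains open whether a methyl, a hydroxyl or an amine there would stay with the hydrogen, chloro and iodo compounds or move the read-out as fluoro does. As far as these compounds go, it is also open whether fluoro would give a similar step on a core in which hydroxyl groups take the place of the two benzyloxy groups.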